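The compounds below may be only part of what the source reports. "The series", "measured", "known", "first", "only" and "open" are said of these compounds alone.

Among the measured compounds shown here, the three compounds measured so far share the core of compound 1 `C=C(CC)C(=O)c1ccc(OCC(=O)NCCO)c(Cl)c1Cl` and differ only in the partner attached to the amide of the side chain. In a functional assay on CLL cells (Homo sapiens) for cytotoxicity, read by MTT assay, with a stated time of 48 h (on this read-out higher numbers stand for an effect only at larger amounts of compound and lower numbers for an effect already at smaller amounts), compound 1 reaches only the assay limit, > 25000 nM. Compound 2 `C=C(CC)C(=O)c1ccc(OCC(=O)Nc2ccc3c(c2)C(=O)NC3=O)c(Cl)c1Cl` gives 2500 nM, and compound 3 `C=C(CC)C(=O)c1ccc(OCC(=O)Nc2ccc(Cl)c(C(=O)O)c2)c(Cl)c1Cl` gives 15900 nM. Compound 1 thus sits at the limit (the limit of > 25000 nM in this assay, at which 1 of the 3 values shown sits), at the weak end of what has been shown. Compound 4 `C=C(CC)C(=O)c1ccc(OCC(=O)NCCCN2CCCC2=O)c(Cl)c1Cl` differs from compound 1 by (2-oxopyrrolidin-1-yl)methyl in place of hydroxy on a saturated chain carbon, two bonds along the chain from an amide-type nitrogen. Both compounds keep a short saturated chain on the amide-type nitrogen, unlike compound 2 and compound 3, so in this assay no movement beyond the scatter is expected. The expected step is a number no higher from compound 1 to compound 4 (the limit leaves the size open). Compound 4 is expected to give 25000 nM, within 8000 nM to 60000 nM.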

Compound 4, half-maximal effective concentration: 13800 nM
Estimate against measurement, compound 4: 1.8-fold (0.26 log units) above; measured number inside the range.
By their numbers in this assay, from the lowest: compound 2; then compounds 4 and 3 (each within the scatter of the next). At a limit, above all of these: compound 1.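

In this assay, (2-oxopyrrolidin-1-yl)methyl in place of hydroxy gives an at least 1.8-fold lower number from compound 1 to compound 4 (0.25 log units; that floor lies within the scatter). Compound 4 thus shows that a short saturated chain on the amide-type nitrogen can give a number short of the limit, which compound 1 did not show. Compound 1 stands at a limit, so the true size of this step stays unknown: the limit of > 25000 nM in this assay, at which 1 of the 4 values shown sits.

Still open, from the compounds shown here alone, is whether the five-membered ring or the added chain length accounts for the step. A plain propyl chain or a chain ending in an amine could separate the two.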